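Notes on a quinoxaline-spiro series against L02 cells

The compounds below may be only part of what the source reports. "The series", "measured", "known", "first", "only" and "open" are said of these compounds alone.

compound 1 `N#CC1=C(N)Oc2c(c3nc4ccccc4nc3c3ccccc23)C12C(=O)N(Cc1cnnn1-c1ccc(F)cc1)c1ccccc12`: > 50000 nM
compound 2 `N#CC1=C(N)Oc2c(c3nc4ccccc4nc3c3ccccc23)C12C(=O)N(Cc1cnnn1-c1ccc(F)c(Cl)c1)c1ccccc12`: > 50000 nM
compound 3 `CCc1ccccc1-n1nncc1CN1C(=O)C2(C(C#N)=C(N)Oc3c(N)cc4nc5ccccc5nc4c32)c2ccccc21`: 22900 nM

Three measured members are available in an ADME assay on L02 cells (Homo sapiens) for antiproliferative activity, read by MTT assay, with a stated time of 48 h; a lower number here means a stronger inhibitor, a higher number a weaker inhibitor. Compound 1 gives only a limit there, > 50000 nM. Compound 2 likewise gives only a limit, > 50000 nM. Between them the change is chloro in place of hydrogen on an aromatic carbon, and a step that the two limits leave unreadable from compound 1 to compound 2 is not readable as a size because of the limit of > 50000 nM in this assay, at which 2 of the 3 values shown sit. Within the data shown here, compound 3 is the only member with a number in this assay, 22900 nM. Compound 1 and compound 2 show only limits, so no ordering of compound 3 against them can be stated.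

Compound 4 `N#CC1=C(N)Oc2c(N)cc3nc4ccccc4nc3c2C12C(=O)N(Cc1cnnn1-c1ccc([N+](=O)[O-])cc1)c1ccccc12` is not yet measured. It differs from compound 3 as follows: 4-nitrophenyl in place of 2-ethylphenyl on an aromatic nitrogen. No measured step changes the group on the aromatic nitrogen, so nothing shown bears directly on this change; the one measured step is unreadable. A step within the usual scatter is therefore expected, with a 1.1-fold higher number from compound 3 to compound 4 (0.04 log units; within the scatter) as the estimate. Compound 4 is expected at 25000 nM, in the range 10000 nM to 60000 nM.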

Compound 4, half-maximal inhibitory concentration: > 50000 nM
Compound 4: no number, only a limit; the forecaster's own chance of this, stated with the estimate: 40%; middle value at least 2.0-fold (0.30 log units) from the limit.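

In this assay, among these compounds, the aryl group on the aromatic nitrogen is the first place where a change gives a readable step: 4-nitrophenyl in place of 2-ethylphenyl gives an at least 2.1-fold higher number from compound 3 to compound 4 (0.33 log units; beyond the scatter). Compound 4 gives > 50000 nM, which is a limit and not a number. The step therefore has a minimum size but no measured size, and the members cannot be ranked further because of this: the limit of > 50000 nM in this assay, at which 3 of the 4 values shown sit.

Going by these compounds, a plain phenyl group on the same nitrogen would help separate the departure of 2-ethylphenyl from the arrival of 4-nitrophenyl, and its reading remains open. Also open, on these data alone, is how an aryl group carrying an amine or a carboxylic acid would read in this assay on this core.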